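This account rests on a few compounds, and the source may have more. Where it says the series, first, only, none or still open, it means among the compounds named here.

Compound 1 (`O=C(Nc1cccc(-n2cc(-c3ccncc3)c(-c3ccc(Cl)c(O)c3)n2)c1)Nc1cccc(C(F)(F)F)c1`) gives 980 nM in a functional assay on MDA-MB-468 cells (Homo sapiens) for inhibition, read by sulforhodamine B assay, with a stated time of 48 h (on this read-out higher numbers stand for weaker inhibition and lower numbers for stronger inhibition), and compound 2 (`COc1cc(-c2nn(-c3cccc(NC(=O)c4cccc(C(F)(F)F)c4)c3)cc2-c2ccncc2)ccc1Cl`) gives 1320 nM on the same read-out. Within the data shown here, these two values lie within the scatter of each other, so compound 2 stands level with the only other measured compound. Among the measured compounds shown here, compound 1 and compound 2 differ in more than one place, and no single-change step has been measured. Compound 3 (`COc1cc(-c2nn(-c3cccc(NC(=O)Nc4ccc(Cl)c(C(F)(F)F)c4)c3)cc2-c2ccncc2)ccc1Cl`) comes from compound 2 by one change on a carbonyl carbon, with (4-chloro-3-(trifluoromethyl)phenyl)amino in place of 3-(trifluoromethyl)phenyl ((4-chloro-3-(trifluoromethyl)phenyl)amino in place of 3-(trifluoromethyl)phenyl on a carbonyl carbon). For the measured compounds named here, compound 1 also has an amino group on its carbonyl carbon and reads 980 nM as the only guide here, which argues against expecting a large step. The expected change is modest and toward lower numbers, with the estimated 1.9-fold lower number from compound 2 to compound 3 (0.28 log units; within the scatter) in this assay possibly staying within the scatter. For compound 3 the estimated value is 700 nM with an expected range from 250 nM to 1900 nM on this read-out.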

Compound 3, half-maximal inhibitory concentration: 830 nM
Beside the measured number, compound 3's estimate is 1.2-fold (0.07 log units) below it; the measured number falls inside the stated range.
By their numbers in this assay, from the lowest: compounds 3, 1 and 2 (each within the scatter of the next).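

Notes on the carbonyl carbon: in this assay, (4-chloro-3-(trifluoromethyl)phenyl)amino in place of 3-(trifluoromethyl)phenyl gives a 1.6-fold lower number from compound 2 to compound 3 (0.20 log units; within the scatter), so the first single-change step in the series stays within the scatter. This position therefore accommodates the entering group, with its added nitrogen, chlorine and hydrogen-bond donor, without a step beyond the scatter on this read-out. The step combines these additions in one change, and no information on hand accounts for this result.

The compounds shown leave open what the amino nitrogen and the chlorine each contribute, since neither appears alone in a single-change step from compound 2 or compound 3. Also open, on these data alone, is whether this carbonyl carbon tolerates a different kind of group, such as morpholine or a plain butyl chain in place of the aryl-bearing groups, or whether such a change would produce a step beyond the scatter.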